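The source may report more compounds than this note shows. Statements on the series, on what has been measured and on what is new or still open speak of the compounds shown alone.

Compound 1 `COc1cc2c(cc1OC)C(CC(=O)O)CC2` is the parent acid of this series. Among the measured compounds shown here, in a functional assay on the whole organism (strain Swiss Albino) for inhibition, with Mus musculus as the target, in the writhing test, with a stated time of 1 h, at a dose of 100 mg/kg by the oral route (on this read-out lower numbers stand for less inhibition and higher numbers for more inhibition at the one dose given (going by the name of the read-out)), compound 1 gives 44%, the lowest of the three numbers measured so far. Compound 2 `COc1cc2c(cc1OC)C(CC(=O)Nc1cccc(Cl)c1)CC2` gives 51.5% in this assay, and compound 3 `COc1cc2c(cc1OC)C(CC(=O)Nc1ccc(Cl)cc1)CC2` gives 73.6%. The step of a number 7.5 percentage points higher from compound 1 to compound 2 (within the scatter) stays within the scatter, whereas a number 29.6 percentage points higher from compound 1 to compound 3 (beyond the scatter) and a number 22.1 percentage points higher from compound 2 to compound 3 (beyond the scatter) both lie beyond it, so only the 4-chlorophenyl amide shows a real gain over the acid.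

Compound 4 `COc1cc2c(cc1OC)C(CC(=O)Nc1ccc(Br)cc1)CC2` has not yet been measured in this assay. It differs from compound 1 in one place: (4-bromophenyl)amino in place of hydroxy on a carbonyl carbon. For the measured compounds named here, the closest precedent is the step to compound 3, which also replaced the hydroxy with a para-substituted aryl amine, and on that basis a modest rise beyond the scatter is expected, because the step of a number 29.6 percentage points higher from compound 1 to compound 3 (beyond the scatter) was of that size. A smaller outcome like that of compound 2 cannot be ruled out. For compound 4 the expected step is a number 26 percentage points higher from compound 1 to compound 4 (beyond the scatter), giving an estimate of 70%, with a range from 52% to 85%.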

Compound 4, a percentage reported as inhibition, in the whole organism at one dose (the size of the read-out at that dose, not a potency): 37.5%
Beside the measured number, compound 4's estimate is 32.5 percentage points above it, outside the stated range (below it).
By their numbers in this assay, from the lowest: compounds 4, 1 and 2 (each within the scatter of the next, the first and the last beyond it); then compound 3.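

With only bromo in place of chloro on an aromatic carbon, the result is a number 36.1 percentage points lower from compound 3 to compound 4 (beyond the scatter) in this assay and the gain seen with the 4-chlorophenyl amide does not carry over to the 4-bromophenyl amide. The comparison with the 3-chlorophenyl amide gives a number 14 percentage points lower from compound 2 to compound 4 (beyond the scatter) and the comparison with the parent acid gives a number 6.5 percentage points lower from compound 1 to compound 4 (within the scatter) and this shows that putting a halogen-bearing phenylamino group in place of hydroxy on the carbonyl carbon does not by itself raise the number, with compound 3 the one exception among these amides. Nothing available explains this difference between the two halogens.

On these data alone, it remains open whether a 4-fluorophenyl or 4-methylphenyl amide would read like compound 3 or like compound 4. As far as these compounds go, the effect of a 3-bromophenyl amide or of an unsubstituted phenyl amide on the shared core is also open.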